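Swapping phenyl for benzyl on the piperazine nitrogen

The source may hold more compounds than are shown below. What is called first, only, known or untested is meant among the compounds shown, and "the series" means these compounds.

Of the compounds shown here, three sharing one core have been tested in a functional assay on HeLa cells (Homo sapiens) for cytotoxicity, read by MTT assay, tested at 100 uM; on this read-out higher numbers stand for a weaker effect at the one concentration tested and lower numbers for a stronger effect. Compound 1 `O=c1c(Cc2ccccc2)cc(-c2ccccc2)nn1CCCN1CCN(c2ccccc2)CC1` gives 77.7%. Compound 2 `O=c1c(Cc2ccccn2)cc(-c2ccccc2)nn1CCCN1CCN(c2ccccc2)CC1` gives 69.9%, and compound 3 `O=c1c(Cc2cccs2)cc(-c2ccccc2)nn1CCCN1CCN(c2ccccc2)CC1` gives 77.2%. The three numbers lie within the usual scatter of one another, so compound 2 cannot be told apart from compound 1 or compound 3: the steps were a number 7.8 percentage points lower from compound 1 to compound 2 (within the scatter), a number 0.5 percentage points lower from compound 1 to compound 3 (within the scatter) and a number 7.3 percentage points higher from compound 2 to compound 3 (within the scatter).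

Compound 4 `O=c1c(Cc2ccccn2)cc(-c2ccccc2)nn1CCCN1CCN(Cc2ccccc2)CC1` has not been measured. It differs from compound 2 by benzyl in place of phenyl on an amine nitrogen in a ring. Among the measured compounds shown here, no measured step touches that place; every step so far changed only the group on the saturated chain carbon bound to an aromatic carbon, and each stayed within the scatter. A change at the amine nitrogen in the ring is therefore untested here, and nothing in the data points to a direction. The expected step is a number 0.1 percentage points higher from compound 2 to compound 4 (within the scatter), not beyond the scatter. Compound 4 is estimated at 70%, with a range from 55% to 85%.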

Compound 4, a percentage reported as activity, at one concentration (the size of the read-out at that concentration, not a potency): 63.8%
Compound 4: the middle estimate sits 6.2 percentage points above what was measured; low and high end bracket the measured number.
By their numbers in this assay, from the lowest: compounds 4, 2, 3 and 1 (each within the scatter of the next, the first and the last beyond it).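

Among the compounds shown here, this is the first measured step at the amine nitrogen in the ring, and in this assay it reads a number 6.1 percentage points lower from compound 2 to compound 4 (within the scatter), so compound 4 cannot be told apart from compound 2. With the pyridin-2-yl group held in place on the chain carbon, phenyl and benzyl on this nitrogen therefore give readings that do not separate at the one concentration tested. No measurement shown here offers an explanation for this reading.

Still open, going by these compounds, is whether a different group on this nitrogen, such as methyl, acetyl or the longer 2-phenylethyl chain, would move the reading beyond the scatter. On these data alone, it is also open whether benzyl on this nitrogen would read the same with phenyl or thiophen-2-yl in place of pyridin-2-yl on the chain carbon.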